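Methyl in Place of Chloro on an Inactive Sulfonamide

The source may report more compounds than this note shows. Statements on the series, on what has been measured and on what is new or still open speak of the compounds shown alone.

Measured compounds:
compound 1, `O=S(=O)(Nc1ccc(-c2nc3ccccc3o2)cc1)c1ccccc1Cl`, > 63000 nM
compound 2, `O=S(=O)(Nc1ccc2oc(-c3ccccc3)nc2c1)c1ccc(Cl)cc1`, > 63000 nM

In an assay on isolated protein for inhibition of malate dehydrogenase, mitochondrial (Sus scrofa), with stated times of 45 min and 30 min (on this read-out higher numbers stand for weaker inhibition and lower numbers for stronger inhibition), compound 1 gives > 63000 nM, which is a limit of the assay rather than a number. In this assay compound 2 gives > 63000 nM, again a limit. Since (the limit of > 63000 nM in this assay, at which 2 of the 2 values shown sit), compound 1 cannot be placed above or below compound 2 on the numbers shown; both merely sit at the limit.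

Compound 3, `Cc1ccccc1S(=O)(=O)Nc1ccc(-c2nc3ccccc3o2)cc1`, differs from compound 1 by methyl in place of chloro on an aromatic carbon, the change reading 2-chlorophenyl to 2-methylphenyl when cut one bond further out. Going by the values given here, no step between measured compounds is available for comparison. The expectation is that the step that the limit leaves unreadable from compound 1 to compound 3 will be none beyond the usual scatter, with compound 3 most likely remaining at the limit. Compound 3 is therefore estimated at 100000 nM, in the range 30000 nM to 400000 nM.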

Compound 3, half-maximal inhibitory concentration: > 63000 nM
Compound 3 ended at the assay's limit; the forecaster's own chance of this, stated with the estimate: 85%; the middle value lies beyond the limit too.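

Compound 1 and compound 3 yield no readable step for methyl in place of chloro, because each result is only a limit: the limit of > 63000 nM in this assay, at which 3 of the 3 values shown sit.

The compounds shown leave open whether either group affects inhibition at all, and what structure would give a measurable value.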